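Hydroxy in Place of Methoxy on a Shared Core

The source may hold more compounds than are shown below. What is called first, only, known or untested is meant among the compounds shown, and "the series" means these compounds.

Of the compounds shown here, three sharing one core have been tested in a functional assay on ACHN cells (Homo sapiens) for inhibition, read by sulforhodamine B assay, with a stated time of 48 h; on this read-out higher numbers stand for weaker inhibition of growth and lower numbers for stronger inhibition of growth. Compound 1 `COc1cc(C)cc(-c2nn(CC#N)cc2-c2ccc(-c3cccc(C(C)=O)c3)nc2)c1` gives 4190 nM, compound 2 `Cc1cc(O)cc(-c2nn(CC#N)cc2-c2ccnc(-c3ccc(Oc4ccccc4)cc3)c2)c1` gives 2840 nM, and compound 3 `COc1cc(C)cc(-c2nn(CC#N)cc2-c2ccnc(-c3ccc(N(C)C)cc3)c2)c1` gives 499 nM. Compound 3 stands at the lowest number of the three, beyond the scatter from both others, so it is the strongest growth inhibitor among them. Compound 4 `Cc1cc(O)cc(-c2nn(CC#N)cc2-c2ccnc(-c3ccc(N(C)C)cc3)c2)c1` has not yet been measured. It differs from compound 3 in one place: hydrogen in place of methyl on an oxygen on an aromatic ring. Among the compounds with values here, no measured pair shows this change alone, so the expected step in this assay is modest, leaning toward a slightly higher number and possibly within the scatter, as a 1.5-fold higher number from compound 3 to compound 4 (0.18 log units; within the scatter) expresses. Compound 4 is estimated to give 750 nM, with a range from 250 nM to 2200 nM.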

Compound 4, concentration for 50% growth inhibition: 3730 nM
Beside the measured number, compound 4's estimate is 5.0-fold (0.70 log units) below it, outside the stated range (above it).
By their numbers in this assay, from the lowest: compound 3; then compounds 2, 4 and 1 (each within the scatter of the next).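

Within the data shown here, replacing methoxy with hydroxy on the aromatic ring is the only change in a 7.5-fold higher number from compound 3 to compound 4 (0.87 log units; beyond the scatter), so removing that single methyl clearly weakens growth inhibition in this assay. With the hydroxy kept, dimethylamino in place of phenoxy gives a 1.3-fold higher number from compound 2 to compound 4 (0.12 log units; within the scatter), so this swap has no clear effect in that setting. Nothing here explains why the methyl matters. Open, on these data alone, is whether ethoxy, with its longer chain on the oxygen, would hold the activity of methoxy. As far as these compounds go, an amine in place of the hydroxy also remains untested in these compounds.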